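Heteroaryl swap on the thioether of the shared core

The source may hold more compounds than are shown below. What is called first, only, known or untested is meant among the compounds shown, and "the series" means these compounds.

Measured so far:
compound 1 `Cn1c(-c2ccc(NC(=O)CSc3nc4cc(Cl)ccc4o3)cc2)nc(-c2ccccc2)c1-c1ccccc1` — 79.6%
compound 2 `Cc1nnc(SCC(=O)Nc2ccc(-c3nc(-c4ccccc4)c(-c4ccccc4)n3C)cc2)s1` — 90.5%

In a functional assay on HT-29 cells (Homo sapiens) for cytotoxicity, read by MTT assay, with a stated time of 24 h, tested at 80 ug/mL (a lower number here means a weaker effect, a higher number a stronger effect of the compound at the concentration tested), compound 1 gives 79.6% and compound 2 gives 90.5%. Compound 2 therefore stands highest of the two numbers; its nearest neighbour is compound 1, separated by a number 10.9 percentage points higher from compound 1 to compound 2 (beyond the scatter).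

Compound 3 `Cn1c(-c2ccc(NC(=O)CSC3=NCCS3)cc2)nc(-c2ccccc2)c1-c1ccccc1` is not yet measured. It differs from compound 2 in one place: a group of 5 heavy atoms (3 carbon, 1 nitrogen, 1 sulfur; one five-membered non-aromatic ring with 2 hetero atoms) in place of a group of 6 heavy atoms (3 carbon, 2 nitrogen, 1 sulfur; one five-membered aromatic ring with 3 hetero atoms), on a sulfur. For the measured compounds named here, the only step that bears on this position is the one from compound 1 to compound 2, a number 10.9 percentage points higher from compound 1 to compound 2 (beyond the scatter), which changed the group on the same sulfur and gave a modest gain. Going by the values given here, no measured step puts a non-aromatic ring of the kind that enters here on that sulfur, so the size of the new step cannot be read off a precedent; both numbers so far sit high, which leaves more room downward than upward.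

The working expectation for compound 3 is a step of a number 10.5 percentage points lower from compound 2 to compound 3 (beyond the scatter) from compound 2, with the result estimated at 80%, within a range from 60% to 95%.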

Compound 3, a percentage reported as activity, at one concentration (the size of the read-out at that concentration, not a potency): 75.2%
For compound 3 the middle estimate is 4.8 percentage points above the measured one; low and high end bracket the measured number.
By their numbers in this assay, from the lowest: compounds 3 and 1 (each within the scatter of the next); then compound 2.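

In this assay, the non-aromatic ring on the sulfur gives a number 15.3 percentage points lower from compound 2 to compound 3 (beyond the scatter), so the 5-methyl-1,3,4-thiadiazol-2-yl group of compound 2 now stands apart from two different replacements rather than one. Set against the two-ring 5-chloro-1,3-benzoxazol-2-yl group, the same non-aromatic ring gives a number 4.4 percentage points lower from compound 1 to compound 3 (within the scatter), which means that a one-ring group and a two-ring group can sit within the scatter of each other at this position, and group size alone does not order the three compounds, since compound 2, with the group of intermediate size, is the one that stands apart. Nothing measured on these compounds speaks to the cause of either step.

The three compounds cannot separate the contribution of the aromatic ring from that of the methyl group or the ring's hetero atoms, a question that an unsubstituted 1,3,4-thiadiazol-2-yl group would bear on directly. Going by these compounds, how an amine, a carboxylic acid or a longer chain on the same sulfur would read remains open, as does whether the stronger effect of compound 2 seen at the single concentration of this assay would hold at other concentrations.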